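The source may report more compounds than this note shows. Statements on the series, on what has been measured and on what is new or still open speak of the compounds shown alone.

The measured compounds:

compound 1, `Cc1ccc(NC(=O)N[C@H](C)c2ccccc2)cc1`, gives 100% in an ADME assay on the whole organism with Oryza sativa as the target, tested at 0.1 uM; on this read-out lower numbers stand for a stronger effect and higher numbers for a weaker effect at the one concentration tested
compound 2, `Cc1ccc(NC(=O)N[C@@H](C)c2ccccc2)cc1`, gives 100%
compound 3, `C[C@@H](NC(=O)Nc1ccccc1C(F)(F)F)c1ccccc1`, gives 99%

All three numbers lie within the usual scatter of one another, so compound 1 stands level with compound 2 at the digits shown, and compound 3 is no different from either in any meaningful sense. Among the compounds with values here, the only step that can be followed one change at a time is the one from compound 1 to compound 2, where the read-out shows no change at the digits printed from compound 1 to compound 2 (within the scatter), which is what one would expect because of the fact that compounds 1 and 2 differ only in the configuration as drawn.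

Compound 4, `CC(=O)c1ccc(NC(=O)N[C@H](C)c2ccccc2)cc1`, is not yet measured. Compared with compound 1 the change is acetyl in place of methyl on an aromatic carbon. Within the data shown here, no measured step here alters a group on that aromatic ring, so the single measured step offers no direct guide to this change. What the data do show is that three compounds of rather different make-up all sit at the same level, which points to a read-out that moves little across this set. For that reason the step to compound 4 is expected to be a number 3 percentage points lower from compound 1 to compound 4 (within the scatter), that is, nothing beyond the scatter. Compound 4 is therefore estimated to give 97%, within a range from 85% to 100%.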

Compound 4, a percentage reported as activity, at one concentration (the size of the read-out at that concentration, not a potency): 96%
Compound 4: middle estimate off by 1 percentage points, on the high side; the measured number falls inside the stated range.
By their numbers in this assay, from the lowest: compounds 4, 3, 1 and 2 (each within the scatter of the next).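

In this assay the read-out shows a number 4 percentage points lower from compound 1 to compound 4 (within the scatter), and this is the only step shown that alters a group on an aromatic carbon of the six-membered ring, para to a large group; the one earlier step changed only the configuration as drawn. Within the data shown here, at this position, then, replacing methyl, with its single heavy atom and no hydrogen-bond acceptor, by acetyl, with three heavy atoms and a hydrogen-bond acceptor, leaves the number within the scatter, which the earlier compounds could not show. Nothing known about these compounds speaks to why the number stays within the scatter for this change.

Among the compounds shown, no amine, carboxylic acid or longer chain sits at this position, so it remains open whether any group there can move the number beyond the scatter. Because all the steps shown stay within the scatter and each compound has a value at only one concentration, it also remains open which changes to the shared core, if any, would give a clearly stronger effect.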